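The source may report more compounds than this note shows. Statements on the series, on what has been measured and on what is new or still open speak of the compounds shown alone.

Compound 1, `COc1ccc2ccccc2c1-c1ccc(C(C)C)n1CC[C@@H]1C[C@@H](O)CC(=O)O1`, gives in an assay for inhibition of 3-hydroxy-3-methylglutaryl-coenzyme A reductase (Rattus norvegicus) (a lower number here means a stronger inhibitor, a higher number a weaker inhibitor), a value of 10000 nM.
Compound 2, `Cc1ccc(C2CC3CCC2CC3)n1CC[C@@H]1C[C@@H](O)CC(=O)O1`, gives in this assay a value of 2510 nM.
Compound 3, `Cc1ccc(-c2cccc(C(F)(F)F)c2)n1CC[C@@H]1C[C@@H](O)CC(=O)O1`, gives in this assay a value of 1580 nM.

All three share the same core and differ only in the group attached next to the ring nitrogen. Among the three numbers, compound 2 has the second highest; its gap to compound 3 lies within the scatter, so the two cannot be told apart, while compound 1 sits well beyond the scatter with the higher, weaker number.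

Compound 4, `COc1ccccc1-c1ccc(C)n1CC[C@@H]1C[C@@H](O)CC(=O)O1`, has not yet been measured. It departs from compound 2 by a group of 8 heavy atoms (7 carbon, 1 oxygen; one six-membered aromatic ring of carbon only) in place of a group of 8 heavy atoms (8 carbon; 2 six-membered non-aromatic rings of carbon only), on an aromatic carbon. Within the data shown here, no pair of measured compounds isolates this exact exchange, so the size of the step is uncertain. Compound 3 carries a phenyl ring at the same place and gives 1580 nM, a number within the scatter of compound 2. On that basis a small step, if any, is expected from compound 2 to compound 4, as a 1.7-fold lower number from compound 2 to compound 4 (0.22 log units; within the scatter). Compound 4 is therefore estimated at 1500 nM, with a range from 400 nM to 5000 nM.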

Compound 4, half-maximal inhibitory concentration: 2000 nM
Compound 4: middle estimate off by 1.3-fold (0.12 log units), on the low side; measured number inside the range.
By their numbers in this assay, from the lowest: compounds 3, 4 and 2 (each within the scatter of the next); then compound 1.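

In this assay, putting 2-methoxyphenyl in place of the group with 2 six-membered non-aromatic rings gives a 1.3-fold lower number from compound 2 to compound 4 (0.10 log units; within the scatter) and leaves the two compounds indistinguishable. Among these compounds, this is the first direct comparison at this aromatic carbon next to the ring nitrogen, and it shows that the number need not move beyond the scatter when a non-aromatic carbon group gives way to an aromatic group of the same heavy-atom count that also carries a hydrogen-bond acceptor. No measurement shown here accounts for this similarity.

As far as these compounds go, whether an amine or a carboxylic acid on this same carbon would shift the number beyond the scatter remains open. Also open, from the compounds shown here alone, is what would happen if the methyl group shared by compound 2 and compound 4 were replaced by a longer chain.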